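Carbonyl carbon group swap, compound 2 to compound 3

The compounds below may be only part of what the source reports. "The series", "measured", "known", "first", "only" and "open" are said of these compounds alone.

Going by the values given here, in a functional assay on NCI-H460 cells (Homo sapiens) for cytotoxicity, read by MTT assay, with a stated time of 48 h (on this read-out lower numbers stand for stronger inhibition and higher numbers for weaker inhibition), compound 1 `C=C1C(=O)O[C@H]2CC3=C[C@H](C/C(C)=C/[C@@H](OC(=O)/C=C/c4ccc(N(C)C)cc4)[C@H]12)OC3=O` gives 1300 nM and compound 2 `C=C1C(=O)O[C@H]2CC3=C[C@H](C/C(C)=C/[C@@H](OC(=O)C45CCC(C)(C(=O)O4)C5(C)C)[C@H]12)OC3=O` gives 2000 nM, so compound 2 stands within the scatter of the only other number available. The change to compound 3 `C=C1C(=O)O[C@H]2CC3=C[C@H](C/C(C)=C/[C@@H](OC(=O)/C=C/c4ccncc4)[C@H]12)OC3=O` is a group of 8 heavy atoms (7 carbon, 1 nitrogen; one six-membered aromatic ring with 1 hetero atom) in place of a group of 11 heavy atoms (9 carbon, 2 oxygen; one five-membered non-aromatic ring of carbon only, one five-membered non-aromatic ring with 1 hetero atom), on a carbonyl carbon. Among the compounds with values here, the one measured step bearing on it is a 1.5-fold higher number from compound 1 to compound 2 (0.19 log units; within the scatter), another exchange of the group on the carbonyl carbon. With that step so small, no shift beyond the scatter is expected in this assay, and the expected change is a 1.2-fold lower number from compound 2 to compound 3 (0.07 log units; within the scatter). The estimate for compound 3 is 1700 nM, with a range of 600 nM to 5000 nM.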

Compound 3, half-maximal inhibitory concentration: 2100 nM
Beside the measured number, compound 3's estimate is 1.2-fold (0.09 log units) below it, and the stated range covers the measured number.
By their numbers in this assay, from the lowest: compounds 1, 2 and 3 (each within the scatter of the next).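

In this assay the group on the carbonyl carbon can change from the two-ring group of compound 2 to 2-(pyridin-4-yl)ethenyl without leaving the scatter (a 1.1-fold higher number from compound 2 to compound 3 (0.02 log units; within the scatter)). Within the ethenyl pair, pyridin-4-yl in place of 4-(dimethylamino)phenyl also stays within it (a 1.6-fold higher number from compound 1 to compound 3 (0.21 log units; within the scatter)), so all three groups read alike here. No measured evidence explains this.

Still open, going by these compounds, is whether any group at this place moves the number beyond the scatter, such as a carboxylic acid, a primary amine or a longer alkyl chain on the carbonyl carbon.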